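Cyano to hydroxymethyl when only limits are known

The source may report more compounds than this note shows. Statements on the series, on what has been measured and on what is new or still open speak of the compounds shown alone.

In a physicochemical assay for solubility, using the shake flask method, in simulated intestinal fluid, measured as kinetic solubility, with a stated time of 2 h, at 25 degrees C, at pH 6.5 (on this read-out lower numbers stand for lower solubility and higher numbers for higher solubility), compound 3 `Cc1noc(-c2nc(C)c3c(c2N)C(=O)N(Cc2ccc(C#N)cc2)C3=O)n1` gives < 5000 nM, which is a limit of the assay and not a number. Compound 1 `Cc1noc(-c2nc(C)c3c(c2N)C(=O)N(Cc2ccc(OC(F)(F)F)cc2)C3=O)n1` gives < 5000 nM, also a limit. Compound 2 `Cc1noc(-c2nc(C)c3c(c2N)C(=O)N(Cc2ccccc2F)C3=O)n1` gives < 5000 nM, again a limit. The record so far is therefore (the limit of < 5000 nM in this assay, at which 3 of the 3 values shown sit), and compound 3 has no exact place in it.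

Compound 4 `Cc1noc(-c2nc(C)c3c(c2N)C(=O)N(Cc2ccc(CO)cc2)C3=O)n1` carries hydroxymethyl in place of the cyano of compound 3, on an aromatic carbon, para to a large group (hydroxymethyl in place of cyano on an aromatic carbon). Two measured changes bear on this one. Among the compounds with values here, the first is a step that the two limits leave unreadable from compound 1 to compound 3, where cyano replaces trifluoromethoxy. The second is a step that the two limits leave unreadable from compound 2 to compound 3, where 4-cyanophenyl replaces 2-fluorophenyl. Neither has a readable size, so they offer no basis for expecting a change in either direction beyond the usual scatter in this assay. The expected change is a number no lower from compound 3 to compound 4 (the limit leaves the size open). Compound 4 is estimated at about 5000 nM, with an expected range from 2000 nM to 25000 nM.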

Compound 4, solubility: < 5000 nM
Compound 4: only a limit was reported; the forecaster's own chance of this, stated with the estimate: 65%; the middle value sits exactly at the limit.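

In this assay compound 4 gives < 5000 nM, which is a limit and not a number. Its steps from compound 1, compound 2 and compound 3 therefore cannot be read: the limit of < 5000 nM in this assay, at which 4 of the 4 values shown sit.

The compounds shown leave open the actual solubility of each one, and whether swapping these groups changes it at all.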